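The source may report more compounds than this note shows. Statements on the series, on what has been measured and on what is new or still open speak of the compounds shown alone.

Of the compounds shown here, three have been measured in an ADME assay on L6 cells (Rattus norvegicus) for cytotoxicity, read by resazurin assay, with a stated time of 72 h; a lower number here means that less compound is needed, a higher number that more compound is needed for the effect. Compound 1 (`CCOC(=O)C1=C(C)N/C(=C/c2cc(C)n(-c3ccc(SC)cc3)c2C)C1=O`) gives 54000 nM, and compound 2 (`CCOC(=O)C1=C(C)N/C(=C/c2cc(C)n(-c3cccnc3)c2C)C1=O`) gives 160000 nM. Compound 3 (`CC1=C(C(=O)OCc2ccccc2)C(=O)/C(=C\c2cc(C)n(-c3ccccc3C(F)(F)F)c2C)N1`) gives 57000 nM, which lies within the scatter of compound 1 and is a lower number than that of compound 2, a gap beyond the scatter.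

The next compound, compound 4 (`CC1=CC(=O)/C(=C\c2cc(C)n(-c3ccccc3C(F)(F)F)c2C)N1`), differs from compound 3 at one place: hydrogen in place of benzyloxycarbonyl on a double-bonded ring carbon. In words, hydrogen stands in place of benzyloxycarbonyl on a double-bonded ring carbon. Among the compounds with values here, only one step between measured compounds is available, a 3.0-fold higher number from compound 1 to compound 2 (0.47 log units; beyond the scatter), and it concerns a different change, on an aromatic nitrogen. It therefore offers a guide to the likely size of a step, but says nothing directly about this place. Within the data shown here, no measured pair shows what removing the benzyloxycarbonyl does in this assay. A modest step of similar size is therefore expected, tentatively towards a higher number, though a result within the scatter of compound 3 remains possible. The expected step is a 2.1-fold higher number from compound 3 to compound 4 (0.32 log units; beyond the scatter). For compound 4 the estimate is 120000 nM, with an expected range from 45000 nM to 300000 nM.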

Compound 4, half-maximal effective concentration: 54000 nM
Estimate against measurement, compound 4: 2.2-fold (0.35 log units) above, within the range that was stated.
By their numbers in this assay, from the lowest: compounds 1, 4 and 3 (each within the scatter of the next); then compound 2.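

In this assay, removing the benzyloxycarbonyl from the double-bonded ring carbon gives a 1.1-fold lower number from compound 3 to compound 4 (0.02 log units; within the scatter), so a group of 10 heavy atoms, with its six-membered aromatic ring of carbon only and its 2 hydrogen-bond acceptors, can be replaced by hydrogen at this place without a change beyond the scatter. Within the data shown here, the only earlier step, a 3.0-fold higher number from compound 1 to compound 2 (0.47 log units; beyond the scatter), concerned the group on the aromatic nitrogen and lay beyond the scatter, whereas this pair gives the first reading at the ring carbon next to the ring atom that bears a methyl group, and for this pair the benzyloxycarbonyl makes no measurable difference to the number. The compounds shown offer no evidence on why the number holds across this change.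

From the compounds shown here alone, it remains open whether a carboxylic acid, an amine or a longer chain on this carbon would likewise stay within the scatter of compound 4. Among these compounds, this change has also been read with only one group on the aromatic nitrogen, so whether hydrogen in place of benzyloxycarbonyl behaves the same way with pyridin-3-yl or 4-(methylsulfanyl)phenyl there is unknown.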